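Moving the Chlorine from Compound 3 to Compound 4

A few compounds are considered here, and "the series" means these few. Any claim that something is new, unique, unknown or untested is made for them only; others in the source may bear on it.

In a functional assay on HT-29 cells (Homo sapiens) for cytotoxicity, read by sulforhodamine B assay (on this read-out higher numbers stand for weaker inhibition of growth and lower numbers for stronger inhibition of growth), compound 1 `COc1ccc(/C=N\NC(=S)NC(C)(C)CCC[C@](C)(O)[C@@H]2CC=C(C)CC2)cc1` gives 7420 nM and compound 2 `CC1=CC[C@@H]([C@@](C)(O)CCCC(C)(C)NC(=S)N/N=C\c2ccc(O)cc2)CC1` gives 8150 nM as its number. Compound 3 `CC1=CC[C@@H]([C@@](C)(O)CCCC(C)(C)NC(=S)N/N=C\c2ccccc2Cl)CC1` gives 23700 nM and so has the highest number of the three, meaning the weakest inhibition of growth among them.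

Compound 4 `CC1=CC[C@@H]([C@@](C)(O)CCCC(C)(C)NC(=S)N/N=C\c2cccc(Cl)c2)CC1` has the same atoms as compound 3, with 3-chlorophenyl in place of 2-chlorophenyl on a carbon with a double bond to nitrogen. Within the data shown here, no measured step moves a chlorine, so the evidence is only indirect. Changing the group at this same carbon gave modest steps (a 3.2-fold higher number from compound 1 to compound 3 (0.50 log units; beyond the scatter) and a 2.9-fold higher number from compound 2 to compound 3 (0.46 log units; beyond the scatter)), while one smaller change on the ring stayed within the scatter (a 1.1-fold higher number from compound 1 to compound 2 (0.04 log units; within the scatter)). A similarly modest step or less is therefore expected in this assay, more likely towards a lower number than a higher one. The expected step is a 1.6-fold lower number from compound 3 to compound 4 (0.20 log units; within the scatter) in this estimate. For compound 4 the estimated value is 15000 nM with an expected range of 6500 nM to 32000 nM for now.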

Compound 4, concentration for 50% growth inhibition: 6890 nM
Estimate against measurement, compound 4: 2.2-fold (0.34 log units) above, and the stated range covers the measured number.
By their numbers in this assay, from the lowest: compounds 4, 1 and 2 (each within the scatter of the next); then compound 3.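

In this assay, among these compounds, moving the chlorine while keeping the same atoms gives a clear shift (a 3.4-fold lower number from compound 3 to compound 4 (0.54 log units; beyond the scatter)), whereas the earlier steps came only from exchanging one group for a different one. Compound 4 cannot be told apart from the compounds carrying 4-hydroxyphenyl (a 1.2-fold lower number from compound 2 to compound 4 (0.07 log units; within the scatter)) or 4-methoxyphenyl (a 1.1-fold lower number from compound 1 to compound 4 (0.03 log units; within the scatter)), so among these four compounds, only the one with 2-chlorophenyl stands apart, with the highest number. Nothing available here explains why the place of the chlorine on the ring makes this difference.

Going by these compounds, whether 4-chlorophenyl would read like compound 4 or like compound 3 remains open, as does the effect of a bromine or a nitrile on the ring in place of the chlorine. All four compounds share the rest of their structure, so the effect of a change elsewhere, such as an amine in place of the hydroxyl on the chain, is also unknown.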